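A Chlorophenyl Swap on a Shared Core

This account rests on a few compounds, and the source may have more. Where it says the series, first, only, none or still open, it means among the compounds named here.

Of the compounds shown here, three with one shared core have been tested in an assay on isolated protein for inhibition of DNA topoisomerase 1 (Homo sapiens), with a stated time of 30 min, tested at 100 uM; on this read-out lower numbers stand for a weaker effect and higher numbers for a stronger effect at the one concentration tested. Compound 1 `Oc1cccc(-c2cc(-c3ccncc3)nc(-c3cccc(Cl)c3)c2)c1` gives 0%, compound 2 `Oc1cccc(-c2cc(-c3cccc(Cl)c3)nc(-c3ccccn3)c2)c1` gives 0.4%, and compound 3 `Oc1cccc(-c2cc(-c3ccc(Cl)cc3)nc(-c3ccsc3)c2)c1` gives 11.7%, the highest of the three numbers; the gap to compound 2, its nearest neighbour, lies beyond the scatter. For the measured compounds named here, the only measured step, a number 0.4 percentage points higher from compound 1 to compound 2 (within the scatter), changes a different part of the core and lies within the scatter. Compound 4 `Oc1cccc(-c2cc(-c3ccsc3)nc(-c3cccc(Cl)c3)c2)c1` differs from compound 3 by 3-chlorophenyl in place of 4-chlorophenyl on an aromatic carbon. Going by the values given here, no measured step touches the chlorophenyl group, so nothing measured bears directly on this swap. For compound 4 the expected step is a number 2.7 percentage points lower from compound 3 to compound 4 (within the scatter), none beyond the scatter. Compound 4 is therefore estimated at 9%, with a range of 0% to 22%.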

Compound 4, a percentage reported as inhibition, at one concentration (the size of the read-out at that concentration, not a potency): 26.2%
Compound 4: the middle estimate sits 17.2 percentage points below what was measured; measured number outside the range, above it.
By their numbers in this assay, from the lowest: compounds 1 and 2 (each within the scatter of the next); then compound 3; then compound 4.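

In this assay the position of the chlorine alone counts at this place on the shared core: 3-chlorophenyl in place of 4-chlorophenyl gives a number 14.5 percentage points higher from compound 3 to compound 4 (beyond the scatter) even though the two groups hold the same atoms. With 3-chlorophenyl kept, the neighbouring aromatic group counts too, as thiophen-3-yl brings a number 25.8 percentage points higher from compound 2 to compound 4 (beyond the scatter) in place of pyridin-2-yl and a number 26.2 percentage points higher from compound 1 to compound 4 (beyond the scatter) in place of pyridin-4-yl. Nothing at hand explains either change. For the compounds shown here, whether an amine or a carboxylic acid in place of the chlorine would keep this number stays open, and one concentration gives no potency for any compound.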